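Metabolic stability notes on a shared core series

This account rests on a few compounds, and the source may have more. Where it says the series, first, only, none or still open, it means among the compounds named here.

Measured so far:
compound 1 `CN(C[C@H]1Cc2c(cccc2N2CCN(C3COC3)CC2)CN1)[C@H]1CCCc2cccnc21` gives 83.1%;
compound 2 `C[C@@H]1CN(c2cccc3c2C[C@H](CN(C)[C@H]2CCCc4cccnc42)NC3)C[C@H](C)N1` gives 100%;
compound 3 `CN(C[C@H]1Cc2c(cccc2N2CCN3CCC[C@H]3C2)CN1)[C@H]1CCCc2cccnc21` gives 36.6%.

All three were read in an ADME assay on microsomes from liver (Homo sapiens) for metabolic stability, read by LC-MS, with a stated time of 10 min; on this read-out higher numbers stand for a more stable compound and lower numbers for a less stable compound. Compound 1 stands second highest of the three numbers: compound 2 lies a number 16.9 percentage points higher from compound 1 to compound 2 (beyond the scatter), while compound 3 lies a number 46.5 percentage points lower from compound 1 to compound 3 (beyond the scatter). The gap between compound 2 and compound 3 is a number 63.4 percentage points lower from compound 2 to compound 3 (beyond the scatter).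

Compound 4 `CN(C[C@H]1Cc2c(cccc2N2CCN(Cc3ccccn3)CC2)CN1)[C@H]1CCCc2cccnc21` differs from compound 1 in one place: (pyridin-2-yl)methyl in place of oxetan-3-yl on an amine nitrogen in a ring. The group sits on an amine nitrogen in a ring of a six-membered non-aromatic ring with 2 nitrogen.

Among the compounds with values here, none of the measured steps changes the same place as this one. Within the data shown here, the two steps from compound 1 each replace the whole group on the aromatic carbon, so they show only that changes in this region can move the read-out by modest to large amounts in either direction. Among the measured compounds shown here, with no direct precedent, a step downward of moderate size is expected, with wide uncertainty: the estimated step is a number 28.1 percentage points lower from compound 1 to compound 4 (beyond the scatter). For compound 4 the estimate is 55%, within a range from 25% to 85%.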

Compound 4, percent of the compound remaining: 4.2%
Compound 4: the middle estimate sits 50.8 percentage points above what was measured; the whole stated range lies above it.
By their numbers in this assay, from the lowest: compound 4; then compound 3; then compound 1; then compound 2.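

In this assay, the group on the amine nitrogen in a ring proves to be a strong lever on its own: with (pyridin-2-yl)methyl in place of oxetan-3-yl, the read-out shows a number 78.9 percentage points lower from compound 1 to compound 4 (beyond the scatter). The earlier steps shown here replaced the whole group on the aromatic carbon, whereas here the six-membered non-aromatic ring with 2 nitrogen stays and only its substituent changes, so a large loss does not need a change of that ring. Nothing at hand bears on the reason for this step.

On these data alone, it remains open whether the step follows the pyridine ring itself or the methyl link to the amine nitrogen; a simple methyl or an acetyl group at this place would bear on that. A benzyl group there would show how far the pyridine ring nitrogen matters.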